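The source may report more compounds than this note shows. Statements on the series, on what has been measured and on what is new or still open speak of the compounds shown alone.

Three amides have been examined in an assay on isolated protein for inhibition of thiosulfate sulfurtransferase (Homo sapiens), with a stated time of 60 min, in the absence of a further agent (a lower number here means a stronger inhibitor, a higher number a weaker inhibitor), and none of them registered a number. Compound 1, `O=C(Nc1cccc(Cl)c1)c1cccc(Br)c1`, gives > 100000 nM, which is a limit of the assay rather than a measured value. Compound 2, `O=C(Nc1ccc(Sc2nc3ccccc3s2)cc1)c1ccccc1`, likewise gives > 100000 nM, again a limit. Compound 3, `O=C(Nc1ccc(Sc2nc3ccccc3s2)cc1)c1ccccc1O`, gives > 100000 nM, also a limit. The difference between the cores of compound 1 and compound 2 is not broken down here. Compound 3 differs from compound 2 by hydroxy in place of hydrogen on an aromatic carbon, and that step reads a step that the two limits leave unreadable from compound 2 to compound 3, which cannot be read as a size, because of the limit of > 100000 nM in this assay, at which 3 of the 3 values shown sit.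

Compound 4, `O=C(Nc1cccc(Cl)c1)c1cccc(Br)c1O`, has not yet been measured. It differs from compound 1 by hydroxy in place of hydrogen on an aromatic carbon. Among the measured compounds shown here, this is the same kind of change as the one from compound 2 to compound 3, though here the new group sits ortho to a bromo group as well as ortho to a large group. For the measured compounds named here, with every value so far sitting at the limit, the expectation is that compound 4 likewise shows no measurable inhibition; the expected step is a number no higher from compound 1 to compound 4 (the limit leaves the size open). For compound 4 an estimate of 100000 nM in this assay is expected, most likely reported only as a limit.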

Compound 4, half-maximal inhibitory concentration: > 100000 nM
Compound 4 gave a limit, no number (the forecaster's own chance of this, stated with the estimate: 85%); the middle value sits exactly at the limit.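

No size can be read for the step between compound 1 and compound 4, since each gives a limit of the assay and not a number: the limit of > 100000 nM in this assay, at which 4 of the 4 values shown sit. The compounds shown leave open whether hydroxy in place of hydrogen on an aromatic carbon changes inhibition at all in this assay, and whether any of these amides gives a measurable value.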